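This account rests on a few compounds, and the source may have more. Where it says the series, first, only, none or still open, it means among the compounds named here.

Compound 1 `CN(C)C(=O)c1cc2cnc(Nc3ccc(S(=O)(=O)NCCCCN=C=S)cc3)nc2n1C1CCCC1` was tested in a functional assay on A549 cells (Homo sapiens) for inhibition, read by CCK-8 assay, with a stated time of 72 h, tested at 10 uM (a lower number here means a weaker effect, a higher number a stronger effect of the compound at the concentration tested), where compound 1 gives 101%. Its close relative compound 2 `CN(C)C(=O)c1cc2cnc(Nc3ccc(S(=O)(=O)NCCCCCCN=C=S)cc3)nc2n1C1CCCC1` gives 101%, and the step of no change at the digits printed from compound 1 to compound 2 (within the scatter) shows that a larger chain group in this position did not alter the read-out. Compound 3 `CN(C)C(=O)c1cc2cnc(Nc3ccc(C(=O)NCCCCCN=C=S)cc3)nc2n1C1CCCC1` differs from compound 1 by a group of 11 heavy atoms (7 carbon, 2 nitrogen, 1 oxygen, 1 sulfur; no ring) in place of a group of 11 heavy atoms (5 carbon, 2 nitrogen, 2 oxygen, 2 sulfur; no ring), on an aromatic carbon. Within the data shown here, no measured step covers an exchange of this kind; the only step seen changed nothing. Compound 3 is therefore expected to stay at a similar level, with a step of a number 6 percentage points lower from compound 1 to compound 3 (within the scatter). The estimate for compound 3 is 95%, with a range from 70% to 103%.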

Compound 3, a percentage reported as inhibition, at one concentration (the size of the read-out at that concentration, not a potency): 100%
For compound 3 the middle estimate is 5 percentage points below the measured one; the measured number falls inside the stated range.
By their numbers in this assay, from the lowest: compounds 3, 1 and 2 (each within the scatter of the next).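

In this assay the exchange on the aromatic carbon gives a number 1 percentage points lower from compound 1 to compound 3 (within the scatter) and so shows that the read-out holds when the sulfonamide link gives way to a carbonyl-linked group. The earlier step altered only the far end of the chain, whereas this one alters the link attached to the ring itself. No measurement here explains this result. As far as these compounds go, whether an amine or a carboxylic acid in place of the isothiocyanate at the chain end would keep the read-out stays open. A single concentration also leaves any difference in potency among these compounds unresolved.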